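Moving the methoxy group around the ring of compound 3

The source may hold more compounds than are shown below. What is called first, only, known or untested is meant among the compounds shown, and "the series" means these compounds.

The study concerns three measured compounds built on a shared core, with a fourth awaiting measurement. In a functional assay on CHO cells for positive allosteric modulation of metabotropic glutamate receptor 2 (Homo sapiens), read by scintillation counting and GTPgammaS binding, with a stated time of 30 min (a higher number here means that more compound is needed for the effect, a lower number that less compound is needed), compound 1 `CCCn1ccc2c(NCCCc3ccccc3)cccc2c1=O` gives 158 nM, compound 2 `CCCn1ccc2c(NCc3ccccc3)cccc2c1=O` gives 2000 nM, and compound 3 `CCCn1ccc2c(NCc3cccc(OC)c3)cccc2c1=O` gives 316 nM. Compound 3 therefore sits close to compound 1, the two values lying within the scatter of each other, while it stands well apart from compound 2, the step of a 6.3-fold lower number from compound 2 to compound 3 (0.80 log units; beyond the scatter) being beyond the scatter. The step of a 2.0-fold higher number from compound 1 to compound 3 (0.30 log units; within the scatter) shows no change beyond the scatter.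

Compound 4 `CCCn1ccc2c(NCc3ccc(OC)cc3)cccc2c1=O` differs from compound 3 in a single place: 4-methoxyphenyl in place of 3-methoxyphenyl on a saturated chain carbon bound to a nitrogen on an aromatic ring. Within the data shown here, no measured pair isolates this kind of change, so the only bearing steps are indirect. The step of a 6.3-fold lower number from compound 2 to compound 3 (0.80 log units; beyond the scatter) shows that adding a methoxy group to the ring of compound 2 lowered the number modestly, and the step of a 2.0-fold higher number from compound 1 to compound 3 (0.30 log units; within the scatter) shows that compound 3 and compound 1 are indistinguishable within the scatter. Whether moving the methoxy group keeps that gain is not told by the data. The expected step for compound 4 is therefore a 1.3-fold higher number from compound 3 to compound 4 (0.10 log units; within the scatter), with no direction claimed beyond the scatter. Compound 4 is estimated at 400 nM in this assay, within a range of 100 nM to 1600 nM.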

Compound 4, half-maximal effective concentration: 501 nM
Estimate against measurement, compound 4: 1.3-fold (0.10 log units) below; the range from low to high includes it.
By their numbers in this assay, from the lowest: compounds 1, 3 and 4 (each within the scatter of the next, the first and the last beyond it); then compound 2.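

In this assay, exchanging 3-methoxyphenyl for 4-methoxyphenyl on a saturated chain carbon bound to a nitrogen on an aromatic ring gives a 1.6-fold higher number from compound 3 to compound 4 (0.20 log units; within the scatter), so this assay does not separate the two methoxyphenyl groups at this place. The benefit of the methoxy group is therefore not confined to 3-methoxyphenyl, since adding it in the new arrangement gives a 4.0-fold lower number from compound 2 to compound 4 (0.60 log units; beyond the scatter) and leaves a real difference from the unsubstituted phenyl of compound 2. The comparison with phenethyl adds a finer point: the exchange gives a 3.2-fold higher number from compound 1 to compound 4 (0.50 log units; beyond the scatter), a gap beyond the scatter that compound 3 did not show against compound 1, even though compound 3 and compound 4 cannot themselves be told apart.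

The compounds shown leave open whether a hydroxy, ethoxy or dimethylamino group would hold the same level in place of methoxy at either arrangement, and whether a methoxy group on the phenethyl of compound 1 would lower its number as it does for the phenyl of compound 2. Nothing among the data offered explains why these steps fall as they do.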